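Three Triazoles at the Assay Limit and a Fourth

The source may report more compounds than this note shows. Statements on the series, on what has been measured and on what is new or still open speak of the compounds shown alone.

Measured compounds:
compound 1 `COc1ccccc1-c1ncnn1-c1cc(OC)c(OC)c(OC)c1` gives > 10000 nM
compound 2 `COc1cc(-c2ncnn2-c2cccc(N)c2)cc(OC)c1OC` gives > 10000 nM
compound 3 `COc1cc(-c2ncnn2-c2ccc(Cl)cc2Cl)cc(OC)c1OC` gives > 10000 nM

All three values come from a functional assay on A549 cells (Homo sapiens) for antiproliferative activity, read by MTT assay, with a stated time of 72 h; on this read-out higher numbers stand for weaker inhibition and lower numbers for stronger inhibition. In this assay compound 1 stands only at a limit, > 10000 nM, and no number is known for it. Compound 2 likewise sits at the limit > 10000 nM. Compound 3 also remains at the limit > 10000 nM. Among the compounds with values here, the one single-point change among the measured compounds, a step that the two limits leave unreadable from compound 2 to compound 3, is therefore unreadable, and the whole measured picture reduces to the limit of > 10000 nM in this assay, at which 3 of the 3 values shown sit.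

Compound 4 `COc1cc(-n2ncnc2-c2ccc(Cl)cc2)cc(OC)c1OC` is the next compound to be measured in this assay. It differs from compound 1 in one place: 4-chlorophenyl in place of 2-methoxyphenyl on an aromatic carbon. Within the data shown here, no measured step bears on this exchange, and the steps that exist give no size in either direction. What the three measured compounds do show is that three different substituents on the shared core all stay at the limit, which is the only basis for an expectation.

Compound 4 is therefore expected to behave like compound 1, with an estimated step that the limit leaves unreadable from compound 1 to compound 4. The estimate for compound 4 in this assay is 15000 nM, with an expected range from 5000 nM to 50000 nM, and most likely the assay again reports only a limit.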

Compound 4, half-maximal inhibitory concentration: > 10000 nM
Compound 4: only a limit was reported; the forecaster's own chance of this, stated with the estimate: 75%; the middle value does not contradict the limit.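

In this assay compound 4 gives > 10000 nM as a limit and not a number. Within the data shown here, compound 1 also stands only at a limit, so no step from it to compound 4 can be read. The picture stays at a single limit: the limit of > 10000 nM in this assay, at which 4 of the 4 values shown sit. The compounds shown leave open which change on the shared core, if any, would give a measurable value in this assay.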